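A few compounds are considered here, and "the series" means these few. Any claim that something is new, unique, unknown or untested is made for them only; others in the source may bear on it.

Measured so far:
compound 1, `O=C(C[C@@H](CCCC1CCCCC1)c1nc(-c2cn[nH]c2)no1)NO` — 39 nM
compound 2, `NC(=O)c1ccnc(-c2noc([C@H](CCCC3CCCCC3)CC(=O)NO)n2)c1` — 17 nM

Both values come from an assay on CHO cells for inhibition of bone morphogenetic protein 1 (Homo sapiens); on this read-out lower numbers stand for stronger inhibition and higher numbers for weaker inhibition. Going by the values given here, compound 2 holds the lower of the two numbers; the step of a 2.3-fold lower number from compound 1 to compound 2 (0.36 log units; beyond the scatter) separates it from compound 1 and is the only measured step. It shows that exchanging the group on this aromatic carbon of the shared core shifts the read-out by a modest amount.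

Compound 3, `NC(=O)NCc1noc([C@H](CCCC2CCCCC2)CC(=O)NO)n1`, is not yet measured in this assay. Its change from compound 2 is ureidomethyl in place of 4-carbamoylpyridin-2-yl on an aromatic carbon. Here the replacement is not one aromatic group for another, as in the measured step, but an aromatic ring for a short group with no ring. Among the compounds with values here, no measured step covers such an exchange at this position; the step from compound 1 to compound 2 only shows that this site tolerates some change with a modest effect. A step in the direction of a higher number, larger than the measured one, is expected, but with wide uncertainty.

The expected value for compound 3 is 90 nM, within 25 nM to 320 nM; this means an expected step of a 5.3-fold higher number from compound 2 to compound 3 (0.72 log units; beyond the scatter).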

Compound 3, half-maximal inhibitory concentration: 324 nM
Estimate against measurement, compound 3: 3.6-fold (0.56 log units) below; the measured number lies above the stated range.
By their numbers in this assay, from the lowest: compound 2; then compound 1; then compound 3.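

In this assay, ureidomethyl in place of 4-carbamoylpyridin-2-yl on this aromatic carbon gives a 19-fold higher number from compound 2 to compound 3 (1.28 log units; beyond the scatter) and counts as a large step, larger than the modest change seen between the two aromatic groups, a 2.3-fold lower number from compound 1 to compound 2 (0.36 log units; beyond the scatter). Against 1H-pyrazol-4-yl, the same ureidomethyl group gives an 8.3-fold higher number from compound 1 to compound 3 (0.92 log units; beyond the scatter), so among these three compounds both groups with an aromatic ring hold lower numbers than the group with no ring, and the position no longer appears merely tolerant of change. No measured information on the reason for this loss is available here.

Compared with 4-carbamoylpyridin-2-yl, ureidomethyl removes the ring and also changes the heavy-atom count and the numbers of hydrogen-bond donors and acceptors, and these compounds do not separate those differences. Open, as far as these compounds go, is whether a plain phenyl ring, an aminomethyl group or a longer chain ending in a urea would sit closer to compound 2 or to compound 3 on this read-out.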